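The source may report more compounds than this note shows. Statements on the series, on what has been measured and on what is new or still open speak of the compounds shown alone.

Compound 1, `CN(C(=O)c1ccc(Br)cc1)c1ccc2[nH]c(-c3n[nH]c4ccccc34)cc2n1`: 1780 nM
Compound 2, `CN(c1ccc2[nH]c(-c3n[nH]c4ccccc34)cc2n1)S(=O)(=O)c1ccccc1`: 2400 nM

Going by the values given here, in a functional assay on KB cells (Homo sapiens) for antiproliferative activity, read by MTT assay, with a stated time of 72 h (a higher number here means a weaker inhibitor, a lower number a stronger inhibitor), compound 2 stands at the higher of the two numbers, yet the only measured step, a 1.3-fold higher number from compound 1 to compound 2 (0.13 log units; within the scatter), lies within the scatter, so the two compounds cannot be told apart. Compound 3, `COc1ccc(S(=O)(=O)N(C)c2ccc3[nH]c(-c4n[nH]c5ccccc45)cc3n2)cc1`, differs from compound 2 by methoxy in place of hydrogen on an aromatic carbon. Among the compounds with values here, no measured step touches this outer ring, and the one step available was itself within the scatter, so no change beyond the scatter is expected in this assay. Compound 3 is therefore estimated at 2400 nM, with a likely range from 1000 nM to 5500 nM, a step of no change at the digits printed from compound 2 to compound 3 (within the scatter).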

Compound 3, half-maximal inhibitory concentration: 22100 nM
For compound 3 the middle estimate is 9.2-fold (0.96 log units) below the measured one, outside the stated range (above it).
By their numbers in this assay, from the lowest: compounds 1 and 2 (each within the scatter of the next); then compound 3.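

The outer phenyl ring is not a silent part of these molecules: in this assay, methoxy in place of hydrogen gives a 9.2-fold higher number from compound 2 to compound 3 (0.96 log units; beyond the scatter) and so a clearly weaker inhibitor. The earlier pair showed only a change on the nitrogen that could not be told apart, whereas this position para to a large group responds to a small addition. Nothing available accounts for this loss. The compounds shown leave open whether fluoro or methyl at this position would cost as much as methoxy. They also leave open how an amine or a carboxylic acid there would compare.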